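Phenyl for amino on a shared core: displacement data

The compounds below may be only part of what the source reports. "The series", "measured", "known", "first", "only" and "open" are said of these compounds alone.

Compound 1 `CN1CCC[C@H]1[C@@H]1COc2cc(N)ccc2O1`: 3500 nM
Compound 2 `CN1CCC[C@H]1[C@H]1COc2cc(N)ccc2O1`: 8600 nM
Compound 3 `CN1CCC[C@H]1[C@H]1COc2c(N)cccc2O1`: 13000 nM

Of the compounds shown here, three share one core and have been measured in an assay on membranes from HEK293 cells for displacement of a labelled ligand from Neuronal acetylcholine receptor; alpha3/beta4 (Homo sapiens), with a stated time of 5 min; a higher number here means a weaker inhibitor, a lower number a stronger inhibitor. Compound 2 gives 8600 nM, the second highest of the three numbers; compound 3 sits nearest with 13000 nM, within the scatter of compound 2, while compound 1 with 3500 nM lies furthest. Among the compounds with values here, the one step between compounds that differ in a single place is a 2.5-fold higher number from compound 1 to compound 2 (0.39 log units; beyond the scatter), a modest change that rests on (the fact that compounds 1 and 2 differ only in the configuration as drawn).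

Compound 4 `CN1CCC[C@H]1[C@H]1COc2cc(-c3ccccc3)ccc2O1` has not yet been measured. It differs from compound 2 by phenyl in place of amino on an aromatic carbon. Within the data shown here, none of the measured steps concerns a change of this kind: the only step recorded is a change of configuration, and no pair of measured compounds differs by a group on the aromatic ring. There is therefore no measured basis for expecting a step in either direction beyond the scatter in this assay, and the estimate is correspondingly wide. Compound 4 is expected to give 7000 nM, within a range of 1500 nM to 30000 nM. This estimate corresponds to an expected step of a 1.2-fold lower number from compound 2 to compound 4 (0.09 log units; within the scatter).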

Compound 4, inhibition constant: 5800 nM
Beside the measured number, compound 4's estimate is 1.2-fold (0.08 log units) above it, and the stated range covers the measured number.
By their numbers in this assay, from the lowest: compounds 1, 4, 2 and 3 (each within the scatter of the next, the first and the last beyond it).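

Within the data shown here, until this result, no pair of compounds differed by a group on the aromatic ring of the shared core, so nothing was known about what this position accepts. In this assay, putting phenyl in place of amino on this aromatic carbon gives a 1.5-fold lower number from compound 2 to compound 4 (0.17 log units; within the scatter) and so shows that, with this configuration, the measured binding does not depend on keeping the amino group here, even though the entering group is much larger and carries a whole aromatic ring. No evidence at hand bears on this result.

Going by these compounds, whether a hydroxyl, a methoxy group or a pyridyl ring on this carbon would move the number beyond the scatter stays open. So does whether phenyl would leave the number as little moved on the configuration of compound 1 .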